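The compounds below may be only part of what the source reports. "The series", "measured", "known", "first", "only" and "open" are said of these compounds alone.

Measured in a functional assay on QGY cells (Homo sapiens) for cytotoxicity, read by MTT assay, with a stated time of 48 h; on this read-out lower numbers stand for stronger inhibition and higher numbers for weaker inhibition:

- Compound 1 `CCOC(=O)C1(C(=O)Nc2ccccc2Cl)CC1c1cc(OC)c(OC)c(OC)c1`: 36100 nM; 48800 nM (2 entries)
- Compound 2 `CCOC(=O)[C@]1(C(=O)NCc2ccc(C)cc2)C[C@H]1c1cc(OC)c(OC)c(OC)c1`: 32100 nM

Within the data shown here, compound 2 stands at 32100 nM, the only number it has in this assay, and a further entry for it gives no single number. That value lies within the usual scatter of those of compound 1, whose repeat entries are the several entries of compound 1 in this assay, 36100 nM; 48800 nM (2 entries). The two compounds therefore cannot be ranked on these data.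

The next compound is compound 3 `CCOC(=O)[C@]1(C(=O)Nc2ccccc2Cl)C[C@H]1c1cc(OC)c(OC)c(OC)c1`, which has 2-chlorophenyl in place of 4-methylbenzyl on an amide-type nitrogen. Among the measured compounds shown here, no step between measured compounds shows what such a change does. The nearest guide is compound 1, which also carries 2-chlorophenyl on that nitrogen and gives 36100 nM; 48800 nM (2 entries), close to the level of compound 2. No change beyond the scatter is therefore expected, and the expected step is a 1.2-fold higher number from compound 2 to compound 3 (0.10 log units; within the scatter). The estimated value for compound 3 is 40000 nM. Its measurement is expected to fall between 18000 nM and 90000 nM.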

Compound 3, half-maximal inhibitory concentration: 28000 nM
The estimate for compound 3 lay 1.4-fold (0.15 log units) above the measured number; measured number inside the range.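

In this assay, the replacement of 4-methylbenzyl by 2-chlorophenyl on the amide-type nitrogen can now be read directly, as a 1.1-fold lower number from compound 2 to compound 3 (0.06 log units; within the scatter). This exchange alters the group on that nitrogen without moving the number beyond the scatter, so neither group can be placed ahead of the other. Compound 3 at 28000 nM and compound 1 at 36100 nM; 48800 nM (2 entries) also lie within the usual scatter of each other, so no effect of configuration can be read from this pair, whose only difference is this: the fact that one of compounds 1 and 3 is drawn with a defined configuration and the other without, at the place where they differ

On these data alone, all of these numbers sit at one level, so it remains open whether any group on this nitrogen can shift the value beyond the scatter, for instance a chain ending in an amine or a carboxylic acid in place of the 2-chlorophenyl group. Also open, as far as these compounds go, is what the rest of the shared core contributes, such as a carboxylic acid in place of the ethyl ester, and how the mirror-image form of compound 3 would compare.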